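Swapping a Cyclohexyl Ester for a Morpholine Amide

The source may hold more compounds than are shown below. What is called first, only, known or untested is meant among the compounds shown, and "the series" means these compounds.

compound 1, `CC(C)(C)OC(=O)N1CCN(C(=O)Cn2cc(CN3C(=O)C(=O)c4c(Cl)ccc(Cl)c43)nn2)CC1`: > 128000 nM
compound 2, `O=C(Cn1cc(CN2C(=O)C(=O)c3c(Cl)ccc(Cl)c32)nn1)OC1CCCCC1`: 25200 nM

In a functional assay on SW780 cells (Homo sapiens) for inhibition, read by CCK-8 assay, with a stated time of 72 h (on this read-out higher numbers stand for weaker inhibition and lower numbers for stronger inhibition), compound 1 gives > 128000 nM, a limit of the assay rather than a number. Within the data shown here, compound 2 gives 25200 nM, the only number in hand. For compound 1 the value is a limit (the limit of > 128000 nM in this assay, at which 1 of the 2 values shown sits). Compound 3, `O=C1C(=O)N(Cc2cn(CC(=O)N3CCOCC3)nn2)c2c(Cl)ccc(Cl)c21`, differs from compound 2 by morpholin-4-yl in place of cyclohexyloxy on a carbonyl carbon. Among the measured compounds shown here, no measured step covers this change. Compound 1, whose value is a limit > 128000 nM, also carries an amide on that carbonyl. A step toward weaker inhibition is therefore expected, a 2.4-fold higher number from compound 2 to compound 3 (0.38 log units; beyond the scatter). Compound 3 is estimated at 60000 nM, within 20000 nM to 150000 nM.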

Compound 3, half-maximal inhibitory concentration: 113000 nM
For compound 3 the middle estimate is 1.9-fold (0.27 log units) below the measured one; the measured number falls inside the stated range.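

Morpholin-4-yl in place of cyclohexyloxy on a carbonyl carbon gives a 4.5-fold higher number from compound 2 to compound 3 (0.65 log units; beyond the scatter) and is the first step here with a real number at both ends. It shows that this carbonyl position does affect inhibition in these cells, with the amide compound 3 the weaker of the pair. One value in the series remains a limit and not a number: the limit of > 128000 nM in this assay, at which 1 of the 3 values shown sits.

As far as these compounds go, whether the link to the carbonyl or the ring itself matters more stays open. Piperidin-1-yl or cyclohexylamino on the same carbonyl would separate the two.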